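This account rests on a few compounds, and the source may have more. Where it says the series, first, only, none or still open, it means among the compounds named here.

Working notes on the amide series.

Compound 3 `COc1ccc(F)c(-c2ccc3c(NC(=O)c4ccc(N5CCCN(C)CC5)cc4)n[nH]c3c2)c1F` carries 4-methyl-1,4-diazepan-1-yl on the benzamide ring. In a functional assay on SNU-16 cells (Homo sapiens) for antiproliferative activity, read by CCK-8 assay, with a stated time of 72 h (on this read-out higher numbers stand for weaker inhibition and lower numbers for stronger inhibition), compound 3 gives 102 nM, the lowest number among the two measured values. Compound 1 `COc1ccc(F)c(-c2ccc3c(NC(=O)c4ccc(N(C)CCN(C)C)cc4)n[nH]c3c2)c1F` differs only in the amine and in this assay compound 1 gives 366 nM; the step of a 3.6-fold lower number from compound 1 to compound 3 (0.55 log units; beyond the scatter) is beyond the scatter. Compound 2 `CCN1CCN(c2ccc(C(=O)Nc3n[nH]c4cc(-c5cccc(OC)c5F)ccc34)cc2C(F)(F)F)CC1` differs in several places and in this assay compound 2 returns only a limit, > 1000 nM. For the measured compounds named here, that limit is the limit of > 1000 nM in this assay, at which 1 of the 3 values shown sits, and yields no step.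

Compound 4 `COc1ccc(F)c(-c2ccc3c(NC(=O)c4ccc(N5CCN(C(C)=O)CC5)cc4)n[nH]c3c2)c1F` is the next step: 4-acetylpiperazin-1-yl in place of 4-methyl-1,4-diazepan-1-yl on an aromatic carbon. Going by the values given here, no measured step bears directly on this change; the only step in hand, from compound 1 to compound 3, concerns an exchange between two amines, and compound 4 replaces the amine with an acetylated ring. The expectation is therefore uncertain and leans towards a weaker result. Compound 4 is estimated to give 300 nM in this assay, ranging from 90 nM to 1000 nM. This estimate means a step of a 2.9-fold higher number from compound 3 to compound 4 (0.47 log units; beyond the scatter).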

Compound 4, half-maximal inhibitory concentration: 322 nM
Compound 4: middle estimate off by 1.1-fold (0.03 log units), on the low side; measured number inside the range.
By their numbers in this assay, from the lowest: compound 3; then compounds 4 and 1 (each within the scatter of the next). At a limit, above all of these: compound 2.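

At the benzamide position, 4-acetylpiperazin-1-yl in place of 4-methyl-1,4-diazepan-1-yl gives a 3.2-fold higher number from compound 3 to compound 4 (0.50 log units; beyond the scatter) in this assay, so the lower number of compound 3 does not extend to every saturated ring with two nitrogens at this position. Against the open-chain amine, the acetylated ring gives a 1.1-fold lower number from compound 1 to compound 4 (0.06 log units; within the scatter), which sets these two groups level and leaves 4-methyl-1,4-diazepan-1-yl as the only one of the three that stands apart. No measurement in hand bears on the reason for these differences.

Still open, on these data alone, is whether the difference follows the seven-membered ring or the acetyl group, since the two change together in this step. A 4-methylpiperazin-1-yl group or a 4-acetyl-1,4-diazepan-1-yl group on the same core would separate the two.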